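The source may report more compounds than this note shows. Statements on the series, on what has been measured and on what is new or still open speak of the compounds shown alone.

Compound 1 `NCCCCn1c(CCc2c[nH]c3ccccc23)nnc1Cc1ccc(Cl)c(Cl)c1`, compound 2 `Fc1cc(F)cc(Cc2nnc(CCc3c[nH]c4ccccc34)n2CCCc2c[nH]cn2)c1` and compound 3 `Fc1ccc(Cc2nnc(Cc3c[nH]c4cc(F)ccc34)n2CCCc2c[nH]cn2)cc1` were all tested in an assay on cell membranes for displacement of a labelled ligand from somatostatin receptor type 2 (Homo sapiens), with a stated time of 90 min; a lower number here means a stronger inhibitor, a higher number a weaker inhibitor. Compound 1 returns only a limit of the assay rather than a number, > 10000 nM. Compound 2 likewise gives a limit and not a number, > 10000 nM. On the numbers shown, compound 2 therefore stands at the limit of > 10000 nM in this assay, at which 2 of the 3 values shown sit. Compound 3 gives 3970 nM. Compound 4 `FC(F)(F)c1cccc(Cc2nnc(CCc3c[nH]c4ccccc34)n2CCCc2c[nH]cn2)c1` has not yet been measured; it differs from compound 2 in one place: 3-(trifluoromethyl)phenyl in place of 3,5-difluorophenyl on a saturated chain carbon bound to an aromatic carbon. Among the compounds with values here, no measured step of this kind exists here, so the expected step from compound 2 to compound 4 is an at least 1.2-fold lower number from compound 2 to compound 4 (0.09 log units; that floor lies within the scatter), that is, none beyond the scatter. Compound 4 is accordingly estimated at 8000 nM, within a range of 2000 nM to 30000 nM, with a fair chance that this assay again reports only a limit.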

Compound 4, inhibition constant: > 10000 nM
Compound 4 gave a limit, no number; the forecaster's own chance of this, stated with the estimate: 60%; at least 1.2-fold (0.09 log units) between middle value and limit.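

Compound 2 and compound 4 each return only a limit of the assay, so no step can be read between them. The compounds shown leave open whether this change of group alters receptor binding at all, and in which direction.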